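The compounds below may be only part of what the source reports. "The series", "measured", "known", "first", "only" and "open" are said of these compounds alone.

Measured compounds:
- compound 1, `CNC(=O)c1cc(Oc2ccc(/C=C/C(=O)c3ccc([N+](=O)[O-])cc3)cc2)ccn1` — "not determined" (no result reported)
- compound 2, `CNC(=O)c1cc(Oc2ccc(/C=C/C(=O)c3ccc(C)cc3)cc2)ccn1` — "not determined" (no result reported)
- compound 3, `CNC(=O)c1cc(Oc2ccc(C(=O)/C=C/c3cccc(Br)c3)cc2)ccn1` — 3400 nM

Only compound 3 carries a number. In a functional assay on PC-3 cells (Homo sapiens) for cytotoxicity, read by MTT assay, with a stated time of 72 h (a lower number here means a stronger inhibitor, a higher number a weaker inhibitor), compound 3 gives 3400 nM. Compounds 1 and 2 were not taken through this assay, so there is no second number to set against compound 3, and it stands alone; it is neither strongest nor weakest, simply the single measured point in the series.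

Compound 4, `CNC(=O)c1cc(Oc2ccc(C(=O)/C=C/c3ccc(OC)cc3)cc2)ccn1`, shares the core of compound 3 and differs from it in one place: 4-methoxyphenyl in place of 3-bromophenyl on a double-bonded chain carbon bound to a double-bonded chain carbon. Both groups are one six-membered aromatic ring of carbon only, and the count of heavy atoms moves by one, with one hydrogen-bond acceptor entering. Within the data shown here, no measured pair shows what such an exchange does in this assay, so the size and direction of the step rest on nothing more than the single value of compound 3.

The expectation is a step from compound 3 to compound 4 that stays within the scatter, with no direction favoured: a 1.0-fold higher number from compound 3 to compound 4 (0.01 log units; within the scatter). Compound 4 is therefore estimated at 3500 nM, with a range from 1200 nM to 10000 nM.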

Compound 4, half-maximal inhibitory concentration: > 50000 nM
Compound 4: a limit, no number (the forecaster's own chance of this, stated with the estimate: 15%); middle value at least 14-fold (1.15 log units) from the limit.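

In this assay, among these compounds, the exchange of 3-bromophenyl for 4-methoxyphenyl on a double-bonded chain carbon bound to a double-bonded chain carbon is the first change that can be read, and it gives an at least 14-fold higher number from compound 3 to compound 4 (1.16 log units; beyond the scatter). The reading for compound 4 is a limit of the assay and not a number: the limit of > 50000 nM in this assay, at which 1 of the 4 values shown sits. On these data alone, this position is therefore not indifferent to the group it carries in this assay, even though both groups are one six-membered aromatic ring of carbon only, and the full size of the step remains unknown.

This single pair does not separate the effect of exchanging bromine for methoxy from the effect of the different place on the ring; 4-bromophenyl and 3-methoxyphenyl, which would separate the two, are not among the compounds shown. Also open, as far as these compounds go, is how this position would read with an unsubstituted phenyl or with a phenyl ring bearing an amine or a carboxylic acid.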